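Aryl urea series: chloro in place of cyano

The compounds below may be only part of what the source reports. "The series", "measured", "known", "first", "only" and "open" are said of these compounds alone.

The set rests on one shared core. Compound 1 `CC1(C)CN(NC(=S)Nc2cccc(C#N)c2)c2cc(Cl)ccc2O1` and compound 2 `CC1(C)CN(NC(=O)Nc2ccc(C#N)cc2)c2cc(Cl)ccc2O1` have been measured; compound 3 `CC1(C)CN(NC(=O)Nc2ccc(Cl)cc2)c2cc(Cl)ccc2O1` is the next member to go into the assay. In a functional assay on thoracic aorta (Rattus norvegicus) (a lower number here means that less compound is needed, a higher number that more compound is needed for the effect), compound 1 gives only a limit, > 30000 nM, so no number is known for it. In this assay, going by the values given here, compound 2 gives 3700 nM, and this is the only number in the set so far. Among the compounds with values here, compound 1 accounts for the one other recorded value, which is the limit of > 30000 nM in this assay, at which 1 of the 2 values shown sits.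

Compound 3 differs from compound 2 by chloro in place of cyano on an aromatic carbon. Within the data shown here, no step between two measured compounds is available to anchor this change, so the expectation for compound 3 rests on compound 2 alone. The step from compound 2 to compound 3 is expected to be a 1.1-fold higher number from compound 2 to compound 3 (0.03 log units; within the scatter), that is, nothing beyond the usual scatter in either direction. Compound 3 is therefore estimated at 4000 nM in this assay, with a range from 1300 nM to 12000 nM.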

Compound 3, half-maximal effective concentration: 13300 nM
For compound 3 the middle estimate is 3.3-fold (0.52 log units) below the measured one; measured number above the stated range.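

Going by these compounds alone, the 4-cyanophenyl group now has a first readable step: in this assay, the change to 4-chlorophenyl gives a 3.6-fold higher number from compound 2 to compound 3 (0.56 log units; beyond the scatter). Within the data shown here, this place on the aromatic ring, para to a large group, therefore does not tolerate every swap without a shift in the read-out, and of the two groups compared there, the nitrile is the one that needs less compound. No recorded property of either group accounts for the size of this step.

Compound 1 gives only a limit and differs from compound 2 and compound 3 in more than one place, and no step to it can be read: the limit of > 30000 nM in this assay, at which 1 of the 3 values shown sits.
Going by these compounds, whether the shift seen here extends to other groups at the same place, such as a methoxy group, an amine or a carboxylic acid, remains open, as does whether it would recur on a changed core, given that the reading rests on a single pair of compounds.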